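Adding a Methyl to the Phenyl Ring of Compound 3

The source may report more compounds than this note shows. Statements on the series, on what has been measured and on what is new or still open speak of the compounds shown alone.

Of the compounds shown here, three sharing one core have been tested in a functional assay on NCI-H460 cells (Homo sapiens) for cytotoxicity, read by MTT assay, with a stated time of 72 h; on this read-out higher numbers stand for weaker inhibition and lower numbers for stronger inhibition. Compound 1 `COc1cc2c(Oc3ccc(NC(=O)c4cn(-c5ccccc5)nn4)cc3F)ccnc2cc1OCCCN1CCCC1` gives 280 nM. Compound 2 `COc1cc2c(Oc3ccc(NC(=O)c4cn(-c5ccccc5C)nn4)cc3F)ccnc2cc1OCCCN1CCCC1`, which carries a methyl group on its phenyl ring, gives 1260 nM. In compound 3 `COc1cc2c(Oc3ccc(NC(=O)c4cn(-c5ccccc5)nn4)cc3F)ccnc2cc1OCCCN1CCCCC1` a piperidin-1-yl replaces the pyrrolidin-1-yl of compound 1; compound 3 gives 210 nM. Compound 3 shows the lowest of the three numbers, though the step of a 1.3-fold lower number from compound 1 to compound 3 (0.12 log units; within the scatter) is within the usual scatter; only compound 2 sits clearly apart from it.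

Compound 4 `COc1cc2c(Oc3ccc(NC(=O)c4cn(-c5ccccc5C)nn4)cc3F)ccnc2cc1OCCCN1CCCCC1` is the untested partner of compound 3. The change is methyl in place of hydrogen on an aromatic carbon. The same change has already been followed once, from compound 1 to compound 2 on the pyrrolidin-1-yl core, where it produced a 4.5-fold higher number from compound 1 to compound 2 (0.65 log units; beyond the scatter). Because that step a 4.5-fold higher number from compound 1 to compound 2 (0.65 log units; beyond the scatter) was clearly beyond the scatter, the methyl is expected to raise the number again here, and the step from compound 3 to compound 4 in this assay is estimated to be a 4.5-fold higher number from compound 3 to compound 4 (0.66 log units; beyond the scatter). Compound 4 is therefore expected to give about 950 nM in this assay, with a likely range from 400 nM to 2300 nM.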

Compound 4, half-maximal inhibitory concentration: 2100 nM
Estimate against measurement, compound 4: 2.2-fold (0.34 log units) below; the range from low to high includes it.
By their numbers in this assay, from the lowest: compounds 3 and 1 (each within the scatter of the next); then compounds 2 and 4 (each within the scatter of the next).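

Replacing hydrogen with methyl, which turns phenyl into 2-methylphenyl, now has a second example: on the piperidin-1-yl core, this assay shows a 10-fold higher number from compound 3 to compound 4 (1.00 log units; beyond the scatter). The change therefore raises the number on both cores shown, and the two steps agree as closely as two such steps can be expected to: the same change on two cores in this assay, a 4.5-fold higher number (0.65 log units; beyond the scatter) from compound 1 to compound 2 and a 10-fold higher number (1.00 log units; beyond the scatter) from compound 3 to compound 4, 2.2-fold (0.35 log units) apart, within the scatter of two such steps

The exchange of pyrrolidin-1-yl for piperidin-1-yl can now also be read with the methyl in place, where it gives a 1.7-fold higher number from compound 2 to compound 4 (0.22 log units; within the scatter), so this exchange stays within the scatter with or without the methyl: the same change on two cores in this assay, a 1.3-fold lower number (0.12 log units; within the scatter) from compound 1 to compound 3 and a 1.7-fold higher number (0.22 log units; within the scatter) from compound 2 to compound 4, 2.2-fold (0.35 log units) apart, within the scatter of two such steps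

Going by these compounds, only hydrogen and methyl appear at this place on the phenyl ring, so it remains open whether a fluorine, a methoxy group or a longer chain such as ethyl would raise the number as well. These cell numbers also do not show why the methyl raises the number, and they cover just the two cores shown.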